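From Fluoro to Nitro on a Shared Core

The compounds below may be only part of what the source reports. "The series", "measured", "known", "first", "only" and "open" are said of these compounds alone.

Of the compounds shown here, three have been tested in a functional assay on BMDM cells (Mus musculus, strain C57BL/6) for inhibition, with a stated time of 2 days; on this read-out lower numbers stand for stronger inhibition and higher numbers for weaker inhibition. Compound 1 `COc1ccc(-c2cn(CC(=O)Nc3cc(C)on3)nn2)cc1` carries a methoxy group, and in this assay compound 1 gives only the assay's limit of > 30000 nM rather than a number. Compound 3 `Cc1cc(NC(=O)Cn2cc(-c3ccc(F)cc3)nn2)no1` differs from it by fluoro in place of methoxy on an aromatic carbon; in this assay compound 3 likewise gives only a limit of > 30000 nM. The step that the two limits leave unreadable from compound 1 to compound 3 cannot be read, since (the limit of > 30000 nM in this assay, at which 2 of the 3 values shown sit). Among the measured compounds shown here, compound 2 `O=C(Cn1cc(-c2ccc([N+](=O)[O-])cc2)nn1)Nc1nc2ccccc2s1` has a nitro group but also a different amide partner, so no single step connects it to the others; in this assay compound 2 gives 3280 nM, the only number among the three.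

For the measured compounds named here, compound 4 `Cc1cc(NC(=O)Cn2cc(-c3ccc([N+](=O)[O-])cc3)nn2)no1` is the next target. nitro in place of fluoro on an aromatic carbon The only measured step, from compound 1 to compound 3, is unreadable, so it offers no size to lean on. Going by the values given here, the one guide is that the nitro group is present in compound 2, whose value 3280 nM is a real number. The step of an at least 2.0-fold lower number from compound 3 to compound 4 (0.30 log units; that floor lies within the scatter) is therefore expected to move toward stronger inhibition, with low confidence and a fair chance that only a limit is reported again. Compound 4 is estimated at 15000 nM, within 3000 nM to 60000 nM.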

Compound 4, half-maximal inhibitory concentration: 1220 nM
The estimate for compound 4 lay 12-fold (1.09 log units) above the measured number, and the stated range ends above it.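

In this assay, nitro in place of fluoro on the six-membered aromatic ring, para to a large group, gives an at least 24-fold lower number from compound 3 to compound 4 (1.39 log units; beyond the scatter) and turns a limit into a real number on this shared core, while nitro in place of methoxy at the same place gives an at least 24-fold lower number from compound 1 to compound 4 (1.39 log units; beyond the scatter) as well. These two sizes are only floors, because compound 1 and compound 3 stand at a limit rather than at a number: (the limit of > 30000 nM in this assay, at which 2 of the 4 values shown sit). With nitro held in place, 5-methyl-1,2-oxazol-3-yl in place of 1,3-benzothiazol-2-yl on an amide-type nitrogen gives a 2.7-fold lower number from compound 2 to compound 4 (0.43 log units; beyond the scatter) and a smaller but still real change, so both nitro compounds give numbers with either amide partner.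

The compounds shown leave open whether this gain belongs to nitro alone or would also appear with another group at this place, such as a nitrile or an amine. They also leave open how fluoro or methoxy would read alongside the 1,3-benzothiazol-2-yl partner, which would show whether the two changes act independently of each other.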